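The compounds below may be only part of what the source reports. "The series", "measured", "known", "first", "only" and "open" are said of these compounds alone.

Measured so far:
- compound 1 `O=C(/C=C/c1cccc(O)c1)c1cccc(-n2cc(-c3ccc(Cl)cc3)[nH]c2=O)c1`: 1850 nM
- compound 2 `COc1ccc(-c2cn(-c3cccc(C(=O)/C=C/c4ccc(O)c(OC)c4)c3)c(=O)[nH]2)cc1`: 3960 nM

Both compounds share one core and were run in a functional assay on UACC-62 cells (Homo sapiens) for inhibition; on this read-out higher numbers stand for weaker inhibition of growth and lower numbers for stronger inhibition of growth. Compound 1 gives 1850 nM in this assay, and compound 2 gives 3960 nM. Compound 2 stands with the highest of the two numbers; compound 1 lies a step beyond the scatter lower. Among the compounds with values here, the two compounds differ in more than one place, so no single step between them is recorded.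

Compound 3 `COc1cc(/C=C/C(=O)c2cccc(-n3cc(-c4ccc(Cl)cc4)[nH]c3=O)c2)ccc1O` is compound 2 with chloro in place of methoxy on an aromatic carbon on an aromatic carbon of a six-membered aromatic ring of carbon only, para to a large group. Compound 1, which carries the same chloro, gives 1850 nM, but its other part differs from compound 2, so this is no clean guide. A modest step toward stronger growth inhibition is expected, a 1.6-fold lower number from compound 2 to compound 3 (0.20 log units; within the scatter), about the size of the scatter. Compound 3 is estimated at 2500 nM in this assay, within 1000 nM to 6000 nM.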

Compound 3, concentration for 50% growth inhibition: 2740 nM
Beside the measured number, compound 3's estimate is 1.1-fold (0.04 log units) below it, and the stated range covers the measured number.
By their numbers in this assay, from the lowest: compounds 1, 3 and 2 (each within the scatter of the next, the first and the last beyond it).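

In this assay, within the data shown here, the change from 4-methoxyphenyl to 4-chlorophenyl, on an aromatic carbon para to a large group, gives the first one-place comparison at this position (a 1.4-fold lower number from compound 2 to compound 3 (0.16 log units; within the scatter)), so chloro and methoxy cannot be told apart here on this read-out. The change of 4-hydroxy-3-methoxyphenyl in place of 3-hydroxyphenyl likewise cannot be told apart from no change (a 1.5-fold higher number from compound 1 to compound 3 (0.17 log units; within the scatter)). No data are at hand that would explain either step.

Open, going by these compounds, is whether a group of another kind at the same place, such as an amine or a carboxylic acid, would move the number beyond the scatter. Also open, on these data alone, is what the hydroxy and methoxy groups do singly, since the second step alters the substitution pattern as a whole.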